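Swapping Methoxy for Chloro on the Shared Core

The compounds below may be only part of what the source reports. "The series", "measured", "known", "first", "only" and "open" are said of these compounds alone.

Compound 1, `O=C(O)CCn1c(=O)oc2cc(OCc3ccccn3)c(Cl)cc21`: 1.32
Compound 2, `O=C(O)CCn1c(=O)oc2cc(OCC3CC3)c(Cl)cc21`: 2.09
Compound 3, `COc1cc2oc(=O)n(CCC(=O)O)c2cc1Cl`: "not determined" (no result reported)

In a physicochemical assay for lipophilicity, read by HPLC, at pH 7.4 (on this read-out lower numbers stand for lower lipophilicity and higher numbers for higher lipophilicity), compound 1 gives 1.32 and compound 2 gives 2.09. Going by the values given here, the one measured step, a number 0.77 log units higher from compound 1 to compound 2 (beyond the scatter), concerns a group on the chain bound to the ring oxygen, not the position changed here. For compound 3 the result in this assay is "not determined" (no result reported), so compound 4, `O=C(O)CCn1c(=O)oc2cc(Cl)c(Cl)cc21`, has no measured neighbour to start from. The change is chloro in place of methoxy on an aromatic carbon. Among the compounds with values here, because no step bears on this exchange, its size and direction cannot be read from the data; compound 1 and compound 2 only show where the shared core sits with other groups. Compound 4 is estimated at 1.9, expected between 1.3 and 2.5.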

Compound 4, distribution coefficient: 1.61
Estimate against measurement, compound 4: 0.29 log units above; the measured number falls inside the stated range.
By their numbers in this assay, from the lowest: compounds 1 and 4 (each within the scatter of the next); then compound 2.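

In this assay the chloro group on this aromatic carbon, entering for cyclopropylmethoxy, gives a number 0.48 log units lower from compound 2 to compound 4 (beyond the scatter) and, entering for (pyridin-2-yl)methoxy, gives a number 0.29 log units higher from compound 1 to compound 4 (within the scatter) on the same shared core. Chloro therefore stands clearly apart from only one of the two groups it replaces, so the outcome of an exchange here depends on which group leaves. Nothing available explains that difference. The step from compound 3 to compound 4 cannot be read, so the exchange of methoxy for chloro still has no size or direction. Also open, on these data alone, is how a fluoro group or an amine on this aromatic carbon would compare with chloro.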